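The compounds below may be only part of what the source reports. "The series", "measured", "known", "first", "only" and "open" are said of these compounds alone.

Working notes on the series. In a functional assay on DU-145 cells (Homo sapiens) for inhibition, read by trypan blue exclusion, with a stated time of 96 h (on this read-out lower numbers stand for stronger inhibition of growth and higher numbers for weaker inhibition of growth), compound 1 (`COc1cc(OC)c(/C=C(\C(=O)c2ccc(Br)cc2)S(=O)(=O)c2ccc(Br)cc2)c(OC)c1`) gives > 100000 nM, which is a limit and not a number. Compound 3 (`COc1cc(OC)c(/C=C(\C(=O)c2ccc(Cl)cc2)S(=O)(=O)c2ccc(Br)cc2)c(OC)c1`) gives > 100000 nM, which is also a limit. The data so far are dominated by the limit of > 100000 nM in this assay, at which 2 of the 3 values shown sit. Within the data shown here, compound 2 (`CCOc1ccc(/C=C(\C(=O)c2ccc(Cl)cc2)S(=O)(=O)Cc2ccc(F)cc2)cc1OC`) gives 50000 nM, the only true number in this assay.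

Next is compound 4 (`COc1cc(OC)c(/C=C(/Sc2ccc(C)cc2)C(=O)c2ccc(Br)cc2)c(OC)c1`). Its change from compound 1 is (4-methylphenyl)sulfanyl in place of (4-bromophenyl)sulfonyl on a double-bonded chain carbon bound to a carbonyl carbon and a double-bonded chain carbon, with (4-methylphenyl)sulfanyl in place of (4-bromophenyl)sulfonyl on a double-bonded chain carbon bound to a carbonyl carbon and a double-bonded chain carbon.

Among the measured compounds shown here, the one measured step is a step that the two limits leave unreadable from compound 1 to compound 3, for chloro in place of bromo on an aromatic carbon, and it offers no size to carry over. For the measured compounds named here, no measured step changes the group at the chain carbon in question. Going by the values given here, the only guide to scale is compound 2 at 50000 nM, which differs from compound 1 in more than one place. Weak growth inhibition is therefore expected, and compound 4 may well return only a limit again.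

The estimated move is an at least 1.6-fold lower number from compound 1 to compound 4 (0.22 log units; that floor lies within the scatter), toward stronger inhibition if it can be read at all. Compound 4 is estimated at 60000 nM, with an expected range of 15000 nM to 200000 nM.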

Compound 4, concentration for 50% growth inhibition: > 100000 nM
Compound 4: no number, only a limit; the forecaster's own chance of this, stated with the estimate: 50%; middle value at least 1.6-fold (0.22 log units) from the limit.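

In this assay compound 4 gives > 100000 nM, which is a limit and not a number. Compound 1 also gives only a limit, so no step can be read between compound 1 and compound 4. The compounds shown leave open whether (4-methylphenyl)sulfanyl in place of (4-bromophenyl)sulfonyl changes growth inhibition at all, and the data remain dominated by one value: the limit of > 100000 nM in this assay, at which 3 of the 4 values shown sit.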